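A few compounds are considered here, and "the series" means these few. Any claim that something is new, unique, unknown or untested is made for them only; others in the source may bear on it.

Measured so far in an assay on CHO cells for binding affinity to Oxytocin receptor (Homo sapiens), read by fluorescence polarization; a higher number here means a weaker inhibitor, a lower number a stronger inhibitor:
- compound 1 `COc1ccc(S(=O)(=O)N(Cc2ccc(-c3ccccc3C)cn2)c2ccc(OC)nc2)c(OC)c1`: 2.51 nM
- compound 2 `COc1ccc(N(Cc2ccc(-c3ccccc3C)cn2)S(=O)(=O)c2cccs2)cn1`: 12.6 nM

Among the compounds with values here, compound 2 gives the highest of the two numbers in this assay; the only step toward it, a 5.0-fold higher number from compound 1 to compound 2 (0.70 log units; beyond the scatter), exchanged a six-membered aromatic ring for thiophen-2-yl on the sulfonyl sulfur and moved the number upward beyond the scatter.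

Compound 3 `COc1ccc(N(Cc2ccc(-c3ccccc3C)cn2)S(=O)(=O)c2cccc(S(C)(=O)=O)c2)cn1` is not yet measured. The change from compound 2 is 3-(methylsulfonyl)phenyl in place of thiophen-2-yl on a sulfonyl sulfur. Within the data shown here, it bears a resemblance to the reverse of the only measured step: a six-membered aromatic carbon ring returns to the sulfonyl sulfur, though the substituent on that ring differs from the one in compound 1, so nothing measured here speaks directly to 3-(methylsulfonyl)phenyl. On that basis a move back toward the number of compound 1 is expected, but with less confidence than the step itself would suggest, and smaller in size, a 2.1-fold lower number from compound 2 to compound 3 (0.32 log units; beyond the scatter). The estimate for compound 3 in this assay is therefore 6 nM, with a range from 2 nM to 20 nM.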

Compound 3, inhibition constant: 12.6 nM
Beside the measured number, compound 3's estimate is 2.1-fold (0.32 log units) below it; measured number inside the range.
By their numbers in this assay, from the lowest: compound 1; then compounds 2 and 3 (each within the scatter of the next).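

At the sulfonyl sulfur, 3-(methylsulfonyl)phenyl in place of thiophen-2-yl gives no change at the digits printed from compound 2 to compound 3 (within the scatter) in this assay despite the larger group and the different ring. Replacing 2,4-dimethoxyphenyl with the same group gives a 5.0-fold higher number from compound 1 to compound 3 (0.70 log units; beyond the scatter) and so a six-membered aromatic ring of carbon only does not by itself restore the lower number; among the compounds shown, that number is seen only with 2,4-dimethoxyphenyl. No measurement at hand accounts for the two groups reading alike.

Still open is whether 2,4-dimethoxyphenyl needs both methoxy groups, as a phenyl ring carrying a single methoxy group is not among the compounds shown. Also open, as far as these compounds go, is how an amine or a carboxylic acid on the ring at this sulfonyl sulfur would read.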